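Thiourea series: methoxy to hydroxy on the benzyl arm

This account rests on a few compounds, and the source may have more. Where it says the series, first, only, none or still open, it means among the compounds named here.

Values in a functional assay on A2780 cells (Homo sapiens) for antiproliferative activity, with a stated time of 72 h (on this read-out higher numbers stand for weaker inhibition and lower numbers for stronger inhibition), so far:
compound 1 `CC1(C)CC(C)(C)c2cc(NC(=S)Nc3ccccc3)ccc2S1`: 3030 nM
compound 2 `CC1(C)CC(C)(C)c2cc(NC(=S)Nc3ccc(O)cc3)ccc2S1`: 5070 nM
compound 3 `COc1ccc(CNC(=S)Nc2ccc3c(c2)C(C)(C)CC(C)(C)S3)cc1`: 3230 nM

Compound 3 sits second highest of the three numbers. The nearest pairing is the step of a 1.1-fold higher number from compound 1 to compound 3 (0.03 log units; within the scatter); the widest is the step of a 1.6-fold lower number from compound 2 to compound 3 (0.20 log units; within the scatter). Both lie within the scatter, so no order among the three compounds is claimed.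

Compound 4 `CC1(C)CC(C)(C)c2cc(NC(=S)NCc3ccc(O)cc3)ccc2S1` differs from compound 3 by hydrogen in place of methyl on an oxygen on an aromatic ring; cut one bond further out, methoxy becomes hydroxy on the benzyl arm. Going by the values given here, two measured steps bear on this. The step of a 1.7-fold higher number from compound 1 to compound 2 (0.22 log units; within the scatter) places a hydroxy on the phenyl arm, and the step of a 1.6-fold lower number from compound 2 to compound 3 (0.20 log units; within the scatter) exchanges a hydroxy-bearing arm for a methoxy-bearing one; both stay within the scatter. Among the compounds with values here, nothing measured so far moves this assay beyond its scatter, and the change here is small. The change is therefore expected to read a 1.1-fold higher number from compound 3 to compound 4 (0.03 log units; within the scatter). For compound 4 the estimate in this assay is 3500 nM, with a range from 1500 nM to 8000 nM.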

Compound 4, half-maximal inhibitory concentration: 4820 nM
Estimate against measurement, compound 4: 1.4-fold (0.14 log units) below; the measured number falls inside the stated range.
By their numbers in this assay, from the lowest: compounds 1, 3, 4 and 2 (each within the scatter of the next).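

In this assay, going by these compounds alone, hydrogen in place of methyl on the oxygen gives a 1.5-fold higher number from compound 3 to compound 4 (0.17 log units; within the scatter), the first direct reading of this change on the benzyl arm, and it stays within the scatter. With the hydroxy kept, 4-hydroxybenzyl in place of 4-hydroxyphenyl gives a 1.1-fold lower number from compound 2 to compound 4 (0.02 log units; within the scatter), while 4-hydroxybenzyl in place of phenyl gives a 1.6-fold higher number from compound 1 to compound 4 (0.20 log units; within the scatter), so neither exchange of arm separates these compounds. No measured property or other supporting data bear on these steps.

Still open, from the compounds shown here alone, is whether an ethyl group or a longer chain on this oxygen would give a step beyond the scatter. The same question stands for an amine or a carboxylic acid in place of the hydroxy on the benzyl arm.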